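The source may report more compounds than this note shows. Statements on the series, on what has been measured and on what is new or still open speak of the compounds shown alone.

Compound 1 `CCCOC(=O)N1N=C(c2ccccc2)CC1c1cc(OC)c(OC)c(OC)c1` gives > 10000 nM in a functional assay on HT-29 cells (Homo sapiens) for antiproliferative activity, read by MTT assay, with a stated time of 48 h (on this read-out lower numbers stand for stronger inhibition of growth and higher numbers for weaker inhibition of growth), which is a limit of the assay and not a number.
Compound 2 `CCCOC(=O)N1N=C(c2cccc(OC)c2)CC1c1cc(OC)c(OC)c(OC)c1` gives > 10000 nM in this assay, again a limit.
Compound 3 `COC(=O)N1N=C(c2ccccc2)CC1c1ccc(OC)cc1` gives > 10000 nM in this assay, also a limit.

The change from compound 1 to compound 2 is methoxy in place of hydrogen on an aromatic carbon. Its effect on growth inhibition is a step that the two limits leave unreadable from compound 1 to compound 2, since both compounds stop at the limit of > 10000 nM in this assay, at which 3 of the 3 values shown sit. Compound 4 `COC(=O)N1N=C(c2ccccc2)CC1c1ccc(OC)c(OC)c1` has not yet been measured in this assay. It carries the same kind of change relative to compound 3, namely (methoxy in place of hydrogen on an aromatic carbon); here the new group sits ortho to a methoxy group, whereas in compound 2 no such neighbour is named, so the surroundings of the change are not the same. How the core of compound 3 differs from the core of compound 1 is not broken down here.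

Among the compounds with values here, with three of three values sitting at the limit of > 10000 nM in this assay, at which 3 of the 3 values shown sit, no step has yet been read as a number, and the one earlier instance of this change gave a step that the two limits leave unreadable from compound 1 to compound 2. The step from compound 3 to compound 4 is therefore expected to be a step that the limit leaves unreadable from compound 3 to compound 4, and compound 4 is estimated to give 15000 nM, with a likely range from 4000 nM to 60000 nM in this assay, most probably reported again as a limit.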

Compound 4, concentration for 50% growth inhibition: 10700 nM
Beside the measured number, compound 4's estimate is 1.4-fold (0.15 log units) above it; the range from low to high includes it.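

No size can be read for the step from compound 3 to compound 4, as compound 3 has only a limit of the assay and not a number. Limits still dominate the values shown: the limit of > 10000 nM in this assay, at which 3 of the 4 values shown sit.

The compounds shown leave open whether a methoxy group in place of hydrogen on an aromatic carbon changes growth inhibition at all in this assay, and in which direction.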